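Swapping the carbonyl substituent in the series

The source may report more compounds than this note shows. Statements on the series, on what has been measured and on what is new or still open speak of the compounds shown alone.

Measured in an ADME assay on L02 cells (Homo sapiens) for cytotoxicity, read by MTT assay, with a stated time of 48 h; a higher number here means a weaker inhibitor, a lower number a stronger inhibitor:
compound 1 `CCN(CC)CCNC(=O)c1ccc(C(CC)(CC)c2ccc(OCC(O)C(C)(C)C)c(C)c2)n1CC` gives 2500 nM
compound 2 `CCn1c(C(=O)N(C)CCC#N)ccc1C(CC)(CC)c1ccc(OCC(O)C(C)(C)C)c(C)c1` gives 14900 nM

Compound 2 at 14900 nM holds the higher of the two numbers. The next change leads to compound 3 `C#CC(C)OC(=O)c1ccc(C(CC)(CC)c2ccc(OCC(O)C(C)(C)C)c(C)c2)n1CC`, with (1-methylprop-2-yn-1-yl)oxy in place of (2-cyanoethyl)(methyl)amino on a carbonyl carbon. For the measured compounds named here, one measured step bears on this, a 6.0-fold higher number from compound 1 to compound 2 (0.78 log units; beyond the scatter), a modest change at the same carbonyl carbon. Going by the values given here, that step began from a different group, and no measured compound carries the entering group, so it sets no firm size here. Both the leaving and the entering group have no net charge and hold a triple bond outside aromatic rings. A step in this assay no larger than the scatter is therefore expected, with its direction open. The expected change is a 1.2-fold lower number from compound 2 to compound 3 (0.09 log units; within the scatter). Compound 3 is estimated at 12000 nM, with an expected range from 5000 nM to 30000 nM.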

Compound 3, half-maximal inhibitory concentration: 23700 nM
The estimate for compound 3 lay 2.0-fold (0.30 log units) below the measured number; the range from low to high includes it.
By their numbers in this assay, from the lowest: compound 1; then compounds 2 and 3 (each within the scatter of the next).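

In this assay, exchanging (2-cyanoethyl)(methyl)amino for (1-methylprop-2-yn-1-yl)oxy on the carbonyl carbon gives a 1.6-fold higher number from compound 2 to compound 3 (0.20 log units; within the scatter), so here a nitrogen-linked and an oxygen-linked group, each with a triple bond, are not told apart. The second exchange away from (2-(diethylamino)ethyl)amino gives a 9.5-fold higher number from compound 1 to compound 3 (0.98 log units; beyond the scatter), so compound 1 now stands apart from two different replacements rather than one, and neither compound 2 nor compound 3 goes against this. No available data explain either step.

Still open, on these data alone, is whether the separation of compound 1 follows the diethylamino end of its chain or the amide hydrogen, which a shorter dimethylaminoethyl amide or a piperidine-bearing chain at the same carbonyl carbon could help separate. As far as these compounds go, how a carboxylic acid or a primary amide there would read also remains open.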